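The source may hold more compounds than are shown below. What is called first, only, known or untested is meant among the compounds shown, and "the series" means these compounds.

Of the compounds shown here, three have been measured in a functional assay on UACC-257 cells (Homo sapiens) for cytotoxicity, read by sulforhodamine B assay, with a stated time of 48 h, tested at 100 uM; a higher number here means a weaker effect of the compound at the concentration tested, a lower number a stronger effect. Compound 1 `COc1cc(-c2cc(/C=C/C(=O)c3ccc(N)cc3)[nH]n2)cc(OC)c1OC` gives -93%. Compound 2 `COc1ccc(-c2cc(/C=C/C(=O)c3ccc(N)cc3)[nH]n2)cc1OC` differs from compound 1 by hydrogen in place of methoxy on an aromatic carbon; in this assay compound 2 gives -96%. That change made a step of a number 3 percentage points lower from compound 1 to compound 2 (within the scatter). Compound 3 `COc1cc(C(=O)/C=C/c2cc(-c3cc(OC)c(OC)c(OC)c3)n[nH]2)cc(OC)c1OC` gives -99%; its value and those of compound 1 and compound 2 are all within the usual scatter of one another, so none of the three can be set apart from the others on this evidence. The difference between the core of compound 3 and the core of compound 1 is not broken down here.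

Compound 4 `COc1ccc(-c2cc(/C=C/C(=O)c3cc(OC)c(OC)c(OC)c3)[nH]n2)cc1OC` has not yet been measured in this assay. Among the compounds with values here, it differs from compound 3 by hydrogen in place of methoxy on an aromatic carbon, which is the same change as the one from compound 1 to compound 2, made at the same kind of place. Because that earlier change produced only a number 3 percentage points lower from compound 1 to compound 2 (within the scatter), the expectation is that the step from compound 3 to compound 4 will be of a similar size, estimated at a number 1 percentage points higher from compound 3 to compound 4 (within the scatter). This rests on a single earlier example and on all three measured values lying close together, so it is a cautious expectation rather than a firm rule. Compound 4 is therefore estimated to give about -98% in this assay, with a likely range from -106% to -88%.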

Compound 4, a percentage reported as activity, at one concentration (the size of the read-out at that concentration, not a potency): -94%
Compound 4: middle estimate off by 4 percentage points, on the low side; the measured number falls inside the stated range.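

Swapping a methoxy for hydrogen on the second core gives, in this assay, a step of a number 5 percentage points higher from compound 3 to compound 4 (within the scatter). Set beside the earlier case, the two steps cannot be told apart, so the change behaves alike on both cores as far as this read-out can show: the same change on two cores in this assay, a number 3 percentage points lower (within the scatter) from compound 1 to compound 2 and a number 5 percentage points higher (within the scatter) from compound 3 to compound 4, 8 percentage points apart, within the scatter of two such steps This supports carrying the change from one core to the other in this series only in a limited sense, since it rests on two pairs of compounds, each read at one concentration, and it gives no potency; it does not show that the two cores would still match at lower concentrations, or that the same would hold on a third core.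

The compounds shown leave open what happens when that methoxy gives way to something other than hydrogen, such as a hydroxyl group, a fluorine atom or a longer ethoxy chain. They also leave open how the read-out would respond if the amine of compound 1 and compound 2 were replaced by a carboxylic acid.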